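Indolyl replaced by tert-butylphenyl on the shared core

A few compounds are considered here, and "the series" means these few. Any claim that something is new, unique, unknown or untested is made for them only; others in the source may bear on it.

Among the compounds with values here, compound 2 `COc1cc(-c2ccnc3cc(-c4ccc5cc[nH]c5c4)nn23)cc(OC)c1OC` gives 125 nM in a functional assay on HeLa cells (Homo sapiens) for inhibition, read by CCK-8 assay, with a stated time of 48 h (on this read-out higher numbers stand for weaker inhibition and lower numbers for stronger inhibition), and is the only compound with a numerical result in this set. Compound 1 `COc1cc(-c2cc3nccc(-c4c[nH]c5ccccc45)n3n2)cc(OC)c1OC` reaches only the assay limit, > 10000 nM. Compound 3 `Cc1ccc(-c2cc3nccc(-c4ccc(F)cc4)n3n2)cc1` likewise stops at the limit, > 10000 nM. Two of the three results therefore sit at the limit (the limit of > 10000 nM in this assay, at which 2 of the 3 values shown sit), and compound 2 stands alone with a measured number. Compound 4 `COc1cc(-c2ccnc3cc(-c4ccc(C(C)(C)C)cc4)nn23)cc(OC)c1OC` differs from compound 2 by 4-(tert-butyl)phenyl in place of 1H-indol-6-yl on an aromatic carbon. Within the data shown here, no step between measured compounds is available, so the size of this kind of change is untested here. The step of a 16-fold higher number from compound 2 to compound 4 (1.20 log units; beyond the scatter) is expected to fall beyond the usual scatter, toward weaker inhibition. The estimate for compound 4 in this assay is 2000 nM, ranging from 400 nM to 10000 nM.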

Compound 4, half-maximal inhibitory concentration: > 10000 nM
Compound 4 was reported as a limit; the forecaster's own chance of this, stated with the estimate: 35%; middle value at least 5.0-fold (0.69 log units) from the limit.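

This gives the series its first single-place comparison: at this aromatic carbon, 4-(tert-butyl)phenyl in place of 1H-indol-6-yl gives an at least 80-fold higher number from compound 2 to compound 4 (1.90 log units; beyond the scatter) in this assay, so the result at this position depends strongly on the group carried there. Compound 4 gives > 10000 nM, which is a limit of the assay and not a number. The step is therefore only a lower bound, because it ends at that limit: the limit of > 10000 nM in this assay, at which 3 of the 4 values shown sit.

Which feature of 1H-indol-6-yl matters remains open. An unsubstituted phenyl or an aminophenyl at this carbon would help separate the ring system from the tert-butyl group.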